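A few compounds are considered here, and "the series" means these few. Any claim that something is new, unique, unknown or untested is made for them only; others in the source may bear on it.

In a functional assay for inhibition, with Homo sapiens as the target (on this read-out lower numbers stand for tighter binding and higher numbers for weaker binding), three compounds on a shared core have been measured so far. Compound 1 `Cc1ccc(C#N)c(OC(C)(C)C2OCC(C/C=C\CCC(=O)O)C(c3cccnc3)O2)c1` carries 2-cyano-5-methylphenyl on an oxygen and gives 15.9 nM as the lowest number. Compound 2 `Cc1ccc(OC(C)(C)C2OCC(C/C=C\CCC(=O)O)C(c3cccnc3)O2)cc1` carries 4-methylphenyl and gives 631 nM as the highest. Compound 3 `CC(C)(Oc1ccccc1F)C1OCC(C/C=C\CCC(=O)O)C(c2cccnc2)O1` carries 2-fluorophenyl and gives 166 nM as the second highest of the three, with one neighbour on either side (a 3.8-fold lower number from compound 2 to compound 3 (0.58 log units; beyond the scatter); a 10-fold higher number from compound 1 to compound 3 (1.02 log units; beyond the scatter)).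

Compound 4 `CSc1ccccc1OC(C)(C)C1OCC(C/C=C\CCC(=O)O)C(c2cccnc2)O1` has methylsulfanyl in place of fluoro on an aromatic carbon, ortho to a large group (methylsulfanyl in place of fluoro on an aromatic carbon). Among the compounds with values here, no measured step makes this exchange, so the evidence is indirect. The change from the aryl group of compound 1 to that of compound 2 is the largest step (a 40-fold higher number from compound 1 to compound 2 (1.60 log units; beyond the scatter)), which shows that this aryl group can move the number a long way. Compound 1 at 15.9 nM also shows that a number well under that of compound 3 at 166 nM is reachable, although compound 1 carries an added methyl group. A modest move towards a lower number is therefore expected, estimated as a 2.4-fold lower number from compound 3 to compound 4 (0.38 log units; beyond the scatter) in this assay with real uncertainty in its direction. For compound 4 the estimated value is 70 nM (expected range 20 nM to 230 nM).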

Compound 4, dissociation constant: 89.1 nM
For compound 4 the middle estimate is 1.3-fold (0.10 log units) below the measured one, and the stated range covers the measured number.
By their numbers in this assay, from the lowest: compound 1; then compounds 4 and 3 (each within the scatter of the next); then compound 2.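

Within the data shown here, the exchange of fluoro for methylsulfanyl on an aromatic carbon, ortho to a large group, gives the first direct reading of this place in (this assay), and the step (a 1.9-fold lower number from compound 3 to compound 4 (0.27 log units; within the scatter)) shows that methylsulfanyl, with its carbon and sulfur, cannot be told apart here from the single fluorine of fluoro. The 2-(methylsulfanyl)phenyl group also stands clearly apart from the other two aryl groups, on one side from 4-methylphenyl (a 7.1-fold lower number from compound 2 to compound 4 (0.85 log units; beyond the scatter)) and on the other from 2-cyano-5-methylphenyl (a 5.6-fold higher number from compound 1 to compound 4 (0.75 log units; beyond the scatter)), so this group does not reach the number set by the cyano-bearing aryl group. Nothing measured in the material shown bears on the reason for any of these steps.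

Still open, from the compounds shown here alone, is whether a methoxy group, a chlorine or an amine on the same aromatic carbon would stay level with fluoro and methylsulfanyl or come closer to compound 1. Also open is how much of the number of compound 1 belongs to its cyano group and how much to its methyl group, as the compounds shown include no plain 2-cyanophenyl group.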